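The source may report more compounds than this note shows. Statements on the series, on what has been measured and on what is new or still open speak of the compounds shown alone.

Compound 1 `C=C[C@@](C)(/C=C/c1ccc(O)c(/C=C/C#N)c1)CCC=C(C)C`, compound 2 `C=C[C@@](C)(/C=C/c1ccc(O)c(/C=C/C(=O)OCC)c1)CCC=C(C)C` and compound 3 `C=C[C@@](C)(/C=C/c1ccc(O)c(/C=C/C(N)=O)c1)CCC=C(C)C` share a core and differ in one place. In an ADME assay on HEK293 cells (Homo sapiens) for cytotoxicity, with a stated time of 72 h (on this read-out higher numbers stand for an effect only at larger amounts of compound and lower numbers for an effect already at smaller amounts), compound 1 gives > 36600 nM, a limit of the assay. Compound 2 gives > 36600 nM, also a limit. Compound 3 gives > 36600 nM, again a limit, so it stands at the limit of > 36600 nM in this assay, at which 3 of the 3 values shown sit. The measured steps are a step that the two limits leave unreadable from compound 1 to compound 2, a step that the two limits leave unreadable from compound 1 to compound 3 and a step that the two limits leave unreadable from compound 2 to compound 3, so they offer no size to carry over. Compound 4 `C=C[C@@](C)(/C=C/c1ccc(O)c(/C=C/C(=O)NCc2ccc(C(F)(F)F)cc2)c1)CCC=C(C)C` carries 4-(trifluoromethyl)benzyl in place of hydrogen on an amide-type nitrogen. With no readable step as a guide, only a modest change is expected, an estimated at least 1.2-fold lower number from compound 3 to compound 4 (0.08 log units; that floor lies within the scatter), toward lower numbers if any. Compound 4 is estimated at 30000 nM, with an expected range of 9000 nM to 60000 nM.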

Compound 4, half-maximal effective concentration: > 36600 nM
Compound 4: no number, only a limit; the forecaster's own chance of this, stated with the estimate: 55%; at least 1.2-fold (0.08 log units) between middle value and limit.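

Compound 3 and compound 4 both give only a limit in this assay, so no step can be read between them: the limit of > 36600 nM in this assay, at which 4 of the 4 values shown sit. The compounds shown leave open what size of effect, if any, a change at the amide-type nitrogen has in this assay.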